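Swapping a Lactam Substituent: Expected Liver Microsome Stability

The source may hold more compounds than are shown below. What is called first, only, known or untested is meant among the compounds shown, and "the series" means these compounds.

Compound 1, `O=C(O)c1cc(-c2cccc(COc3ccc4c(=O)n(C5CCCC5)oc4c3)c2)ccc1Cl`: 35%
Compound 2, `O=C(O)c1cc(-c2cccc(COc3ccc4c(c3)CN(CC3CC3)C4=O)c2)ccc1Cl`: 73%

In an ADME assay on microsomes from liver (Rattus norvegicus) for metabolic stability, with a stated time of 60 min (a higher number here means that more of the compound is left, a lower number that less of the compound is left), compound 2 gives the higher of the two measured numbers, and the gap to compound 1 lies beyond the usual scatter of this kind of measurement. Compound 3, `O=C(O)c1cc(-c2cccc(COc3ccc4c(c3)CN(c3ccccc3)C4=O)c2)ccc1Cl`, has not yet been measured. It differs from compound 2 in one place: phenyl in place of cyclopropylmethyl on an amide-type nitrogen in a ring, so a phenyl group sits on the amide-type nitrogen of the five-membered ring where compound 2 carries a cyclopropylmethyl group. Going by the values given here, no measured pair shows what such a swap does, so the direction of the step cannot be read from the data. The expectation is a step of modest size, a number 13 percentage points lower from compound 2 to compound 3 (beyond the scatter), that may or may not exceed the scatter. Compound 3 is therefore estimated to leave 60% remaining, within a range from 35% to 85%.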

Compound 3, percent of the compound remaining: 100%
Beside the measured number, compound 3's estimate is 40 percentage points below it; measured number outside the range, above it.
By their numbers in this assay, from the lowest: compound 1; then compound 2; then compound 3.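

In this assay, the amide-type nitrogen in the five-membered ring proves to be a place where the substituent matters: phenyl in place of cyclopropylmethyl gives a number 27 percentage points higher from compound 2 to compound 3 (beyond the scatter). Going by these compounds alone, this is the only measured pair here that differs in one place, and it shows that a six-membered aromatic ring of carbon only can stand on this nitrogen with no loss in this read-out, as compound 3 gives 100%. Nothing measured here explains the step.

Within the data shown here, the single pair cannot tell whether the gain follows from the arrival of the phenyl ring or the departure of the cyclopropylmethyl group. Going by these compounds, how a benzyl group, a plain cyclopropyl group or a pyridine ring would behave on this nitrogen remains open.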